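Aryl swaps on the shared core: three measured, one pending

A few compounds are considered here, and "the series" means these few. Any claim that something is new, unique, unknown or untested is made for them only; others in the source may bear on it.

Values in a functional assay on HT-29 cells (Homo sapiens) for inhibition, read by MTT assay, with a stated time of 48 h (a higher number here means a weaker inhibitor, a lower number a stronger inhibitor), so far:
- compound 1 `COc1cc(-c2cc(-c3cccs3)nc(-c3ccccc3)n2)cc(OC)c1OC` gives > 25000 nM, a limit of the assay rather than a number.
- compound 2 `COc1ccc(-c2cc(-c3cc(OC)c(OC)c(OC)c3)nc(-c3ccccc3)n2)cc1` gives 4230 nM.
- compound 3 `COc1cc(-c2cc(-c3ccc(C)cc3)nc(-c3ccccc3)n2)cc(OC)c1OC` gives > 25000 nM, again a limit of the assay.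

Compound 1 stands only at a limit in this assay, and compound 3 sits at the same limit, so the limit of > 25000 nM in this assay, at which 2 of the 3 values shown sit, is where two of the three values rest; only compound 2 carries a number. From compound 1 the readable step is an at least 5.9-fold lower number from compound 1 to compound 2 (0.77 log units; beyond the scatter), whereas a step that the two limits leave unreadable from compound 1 to compound 3 cannot be sized, and an at least 5.9-fold higher number from compound 2 to compound 3 (0.77 log units; beyond the scatter) runs back to the limit.

Compound 4 `COc1ccc(-c2cc(-c3cc(OC)c(OC)c(OC)c3)nc(-c3ccccc3)n2)c(OC)c1` differs from compound 1 by 2,4-dimethoxyphenyl in place of thiophen-2-yl on an aromatic carbon. The entering group carries the methoxy of the 4-methoxyphenyl of compound 2 and adds a second methoxy, for which the measured compounds give no guidance. The step of an at least 5.9-fold lower number from compound 1 to compound 2 (0.77 log units; beyond the scatter) therefore bears most directly, and a move of that kind away from the limit is expected, so an at least 4.1-fold lower number from compound 1 to compound 4 (0.61 log units; beyond the scatter) is the expected step in this assay. As far as these compounds go, the added methoxy is untested, so the range is wide. Compound 4 is estimated at 6000 nM, between 1500 nM and 25000 nM.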

Compound 4, half-maximal inhibitory concentration: > 25000 nM
Compound 4: only a limit was reported; the forecaster's own chance of this, stated with the estimate: 25%; middle value at least 4.1-fold (0.61 log units) from the limit.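

Adding a second methoxy to the 4-methoxyphenyl of compound 2, which gives the 2,4-dimethoxyphenyl of compound 4, returns the series to the limit in this assay, and the reading for compound 4 is a limit of the assay, not a number: an at least 5.9-fold higher number from compound 2 to compound 4 (0.77 log units; beyond the scatter). On this aromatic carbon next to the ring nitrogen, a methoxy on the entering phenyl therefore does not by itself lift a compound off the limit, as compound 4 goes against any such pattern and compound 2 alone keeps a number. The steps to compound 4 from compound 1 and from compound 3 cannot be read, because all three compounds rest at the same limit: the limit of > 25000 nM in this assay, at which 3 of the 4 values shown sit.

The compounds shown leave open whether the second methoxy acts through its presence or through where it sits on the phenyl, and whether a hydroxy group, a fluorine or an amine in its place would keep a number. Also open, as far as these compounds go, is how far compound 1, compound 3 and compound 4 lie past the limit, and no order among them can be given.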